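This account rests on a few compounds, and the source may have more. Where it says the series, first, only, none or still open, it means among the compounds named here.

Measured compounds:
- compound 1 `O=C(CSc1nnc(-c2ccncc2)o1)N/N=C/c1ccc(Br)cc1`: 18600 nM
- compound 2 `COc1ccc(/C=N/NC(=O)CSc2nnc(-c3ccncc3)o2)cc1`: 15800 nM
- compound 3 `O=C(CSc1nnc(-c2ccncc2)o1)N/N=C/c1cccc(C(F)(F)F)c1`: 6520 nM

In a functional assay on HepG2 cells (Homo sapiens) for cytotoxicity, read by MTT assay, with a stated time of 48 h (a lower number here means a stronger inhibitor, a higher number a weaker inhibitor), compound 1 gives 18600 nM, the highest number of the three, although compound 2 stands within the usual scatter of it: the change is a 1.2-fold lower number from compound 1 to compound 2 (0.07 log units; within the scatter). Compound 3 gives 6520 nM, a lower number than compound 1 by a gap beyond the scatter.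

Compound 4 `O=C(CSc1nnc(-c2ccncc2)o1)N/N=C/c1cc(Cl)ccc1O` has not yet been measured. It differs from compound 1 in one place: 5-chloro-2-hydroxyphenyl in place of 4-bromophenyl on a carbon with a double bond to nitrogen. For the measured compounds named here, the only measured step that touches the same ring is the one from compound 1 to compound 2, where exchanging one group for another at that ring left the number essentially unchanged. No measured compound carries a hydroxy group or a chloro group, so the effect of the entering group is not shown directly by the data. On that basis only a small step is expected, probably not beyond the scatter. The expected step is a 1.4-fold lower number from compound 1 to compound 4 (0.16 log units; within the scatter), estimated from the near-flat step between compound 1 and compound 2. Compound 4 is therefore expected to give 13000 nM, with an estimated range from 4500 nM to 38000 nM.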

Compound 4, half-maximal inhibitory concentration: 3970 nM
For compound 4 the middle estimate is 3.3-fold (0.52 log units) above the measured one; the whole stated range lies above it.
By their numbers in this assay, from the lowest: compounds 4 and 3 (each within the scatter of the next); then compounds 2 and 1 (each within the scatter of the next).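

In this assay, the ring on the carbon with a double bond to nitrogen proves able to move the number, which the earlier exchange of bromo for methoxy did not show: 5-chloro-2-hydroxyphenyl gives a 4.7-fold lower number from compound 1 to compound 4 (0.67 log units; beyond the scatter) and a 4.0-fold lower number from compound 2 to compound 4 (0.60 log units; beyond the scatter). Both steps lie beyond the scatter, so the flat result from compound 1 to compound 2 does not hold for every change to this ring, although the hydroxy group and the chloro group enter together here and their shares in the step cannot be separated. Nothing available explains why this change lowers the number.

The compounds shown leave open whether the hydroxy group alone or the chloro group alone would give a step of this size, and whether the same groups would do so at other places on the ring. They also leave open what an amine or a carboxylic acid would do on this ring in place of the hydroxy group, and whether a step of this kind would appear in any test other than this one on HepG2 cells.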